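Methyl removal on the aryl amide of a urotensin receptor series

The source may hold more compounds than are shown below. What is called first, only, known or untested is meant among the compounds shown, and "the series" means these compounds.

In an assay on NIH3T3 cells with Urotensin-2 receptor (Homo sapiens) as the target (on this read-out lower numbers stand for an effect already at smaller amounts and higher numbers for an effect only at larger amounts of compound), compound 2 `Cc1cc(C)c(C(=O)NC(CCN(C)C)c2ccc(Cl)cc2)cc1C` gives 1780 nM, the lower of the two numbers seen so far. Compound 1 `Cc1cccc(C(=O)NC(CCN(C)C)c2ccc(Cl)cc2)c1C` gives 3630 nM in this assay, a gap that lies beyond the usual scatter. Compound 3 `Cc1ccc(C(=O)NC(CCN(C)C)c2ccc(Cl)cc2)c(C)c1` differs from compound 2 by hydrogen in place of methyl on an aromatic carbon. For the measured compounds named here, no measured pair shows such a step, so only a modest move is expected, most likely toward a higher number, as a 1.4-fold higher number from compound 2 to compound 3 (0.15 log units; within the scatter). For compound 3 the estimate in this assay is 2500 nM, within 1000 nM to 6300 nM.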

Compound 3, half-maximal effective concentration: 1550 nM
Compound 3: the middle estimate sits 1.6-fold (0.21 log units) above what was measured; low and high end bracket the measured number.
By their numbers in this assay, from the lowest: compounds 3 and 2 (each within the scatter of the next); then compound 1.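

Hydrogen in place of methyl at this carbon gives a 1.1-fold lower number from compound 2 to compound 3 (0.06 log units; within the scatter), so this assay does not separate the two groups here. 2,4-dimethylphenyl in place of 2,3-dimethylphenyl gives a 2.3-fold lower number from compound 1 to compound 3 (0.37 log units; beyond the scatter), so among these compounds the placing of a methyl shows in the number, while the methyl lost at this carbon does not. Nothing at hand explains either step. Going by these compounds, whether a methoxy group or an amine at this carbon would leave the number as it stands remains open, as does the effect of a phenyl ring carrying no methyl at all.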